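From fluoro to chloro in compound 3

The compounds below may be only part of what the source reports. "The series", "measured", "known", "first", "only" and "open" are said of these compounds alone.

In a functional assay on T29Kt1 cells (Homo sapiens) for cytotoxicity, read by sulforhodamine B assay, with a stated time of 3 days (a lower number here means a stronger inhibitor, a higher number a weaker inhibitor), compound 1 `O=Cc1cn(CCCOc2ccc(Cl)cc2)c2ccccc12` gives 4890 nM. Compound 2 `O=Cc1cn(Cc2ccc(Cl)cc2)c2ccc(F)cc12` gives 9090 nM, and these two numbers lie within the scatter of each other. Compound 3 `O=Cc1cn(Cc2ccc(Cl)cc2)c2ccc(Cl)cc12` carries chloro in place of fluoro on an aromatic carbon. Within the data shown here, no measured pair of compounds shows this kind of change, so nothing beyond the scatter is expected in this assay, in either direction. The estimated 1.3-fold lower number from compound 2 to compound 3 (0.11 log units; within the scatter) is therefore small. Compound 3 is expected at 7000 nM, with an estimated range from 2500 nM to 20000 nM.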

Compound 3, half-maximal inhibitory concentration: 10000 nM
For compound 3 the middle estimate is 1.4-fold (0.15 log units) below the measured one, and the stated range covers the measured number.
By their numbers in this assay, from the lowest: compounds 1, 2 and 3 (each within the scatter of the next, the first and the last beyond it).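

In this assay, among these compounds, putting chloro in place of fluoro gives a 1.1-fold higher number from compound 2 to compound 3 (0.04 log units; within the scatter) and so provides the first comparison of compounds that differ in one place. On this aromatic carbon of the shared core, the assay does not separate fluoro from chloro, although this single pair cannot show how other groups would behave there. No measurement is available that would explain this result. Going by these compounds, whether an amine, a methoxy group or a carboxylic acid on this same carbon would give a number beyond the scatter remains open. The compounds shown also leave open how a change at the aldehyde carbonyl would read.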